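The compounds below may be only part of what the source reports. "The series", "measured", "known", "first", "only" and "open" are said of these compounds alone.

- compound 1 `CCNc1nccc(N2CC[C@H](NC(=O)Nc3ccc(Cl)c(C(F)(F)F)c3)C2)n1` with 99.9% 
- compound 2 `O=C(Nc1ccc(Cl)c(C(F)(F)F)c1)N[C@H]1CCN(c2ccnc(NC3CC3)n2)C1` with 99.9% 

In an ADME assay on a cell-free system (plasma, Mus musculus) for protein binding, compound 2 stands level with compound 1 at the digits shown. Compound 3 `O=C(Nc1ccc(Cl)c(C(F)(F)F)c1)N[C@H]1CCN(c2ccncn2)C1` comes next. The structural change is hydrogen in place of cyclopropylamino on an aromatic carbon in short, hydrogen in place of cyclopropylamino on an aromatic carbon. Among the compounds with values here, the one measured step, cyclopropyl in place of ethyl on a nitrogen on an aromatic ring, is no change at the digits printed from compound 1 to compound 2 (within the scatter) and bears only weakly here, since the data hold no step that removes the whole group. With compound 2 at 99.9% there is little room upward, so any movement is expected towards less binding. The expected step is a 10-fold higher unbound fraction from compound 2 to compound 3 (1.00 log units; beyond the scatter) and would be a modest one. For compound 3 the estimated value is 99% with an expected range of 97% to 99.8% in this assay terms.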

Compound 3, plasma protein binding: 99.3%
Beside the measured number, compound 3's estimate is 1.4-fold (0.15 log units) (unbound fraction) above it; low and high end bracket the measured number.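

In this assay, taking the whole substituent off the aromatic carbon between two ring nitrogen atoms gives a 7.0-fold higher unbound fraction from compound 2 to compound 3 (0.85 log units; beyond the scatter), and the same removal of ethylamino gives a 7.0-fold higher unbound fraction from compound 1 to compound 3 (0.85 log units; beyond the scatter). The earlier change from ethyl to cyclopropyl on the nitrogen left no difference at the digits printed, so among these three compounds a shift appears only when the whole group leaves, and both amino compounds give the same step. Compound 3 still reads 99.3%, so binding to plasma protein stays high even without the group. Nothing at hand gives a reason for this shift.

Open, as far as these compounds go, is whether a plain amino group or a methoxy group on this carbon keeps binding level with compound 2 or moves it towards compound 3. Also open, from the compounds shown here alone, is whether removing the group gives a step of this size when a nitrile replaces the trifluoromethyl group of the shared core.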